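Ethoxy to propoxy on the shared core

This account rests on a few compounds, and the source may have more. Where it says the series, first, only, none or still open, it means among the compounds named here.

The shared core is seen in compound 1 `COc1ccc2c(c1)OC/C(=C\c1ccccc1OC)C2=O`. In a functional assay on brain (Rattus norvegicus, strain Wistar) for inhibition (a lower number here means a stronger inhibitor, a higher number a weaker inhibitor), compound 1 gives > 100000 nM, a limit of the assay rather than a number. Compound 2 `COc1ccc2c(c1)OC/C(=C\c1cc(OC)c(O)c(OC)c1)C2=O` gives 11000 nM in this assay. For the measured compounds named here, compound 3 `CCOc1ccc2c(c1)OC/C(=C\c1ccc(O)c(O)c1)C2=O` gives 11900 nM in this assay, a number within the scatter of the one for compound 2, so the two measured numbers sit together. Compound 4 `CCCOc1ccc2c(c1)OC/C(=C\c1ccc(O)c(O)c1)C2=O` differs from compound 3 by methyl in place of hydrogen on a saturated chain carbon, two bonds along the chain from an oxygen on an aromatic ring. Going by the values given here, no measured pair shows this change, so the data give no direction for it; the expected step is a 1.0-fold higher number from compound 3 to compound 4 (0.00 log units; within the scatter), nothing beyond the scatter. Compound 4 is estimated at 12000 nM, with a range from 4000 nM to 36000 nM.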

Compound 4, half-maximal inhibitory concentration: 11400 nM
Estimate against measurement, compound 4: 1.1-fold (0.02 log units) above; the range from low to high includes it.
By their numbers in this assay, from the lowest: compounds 2, 4 and 3 (each within the scatter of the next). At a limit, above all of these: compound 1.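

For the compounds shown here, as the first measured pair for ethoxy to propoxy, this methyl in place of hydrogen gives a 1.0-fold lower number from compound 3 to compound 4 (0.02 log units; within the scatter) in this assay and so does not separate the two chains. At this place on the chain, the added methyl therefore gives no measured direction for the series.

One pair on one core leaves open whether a longer chain such as butoxy, or an amine at the chain end, would stay within the scatter. Nothing shown bears on why this step is so small.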